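Swapping allyl for phenyl on a weak compound

The source may hold more compounds than are shown below. What is called first, only, known or untested is meant among the compounds shown, and "the series" means these compounds.

- compound 1 `C=Cc1ccc([C@H]2CCN(C)C[C@H]2C(=O)OC)cc1` reads 204 nM
- compound 2 `C=CCc1ccc([C@H]2CCN(C)C[C@H]2C(=O)OC)cc1` reads > 1200 nM (a limit)

In a functional assay (brain) with Rattus norvegicus as the target (on this read-out lower numbers stand for stronger inhibition and higher numbers for weaker inhibition), compound 2 reads > 1200 nM and this is a limit of the assay, not a number. Compound 3 `COC(=O)[C@@H]1CN(C)CC[C@@H]1c1ccc(-c2ccccc2)cc1` differs from it as follows: phenyl in place of allyl on an aromatic carbon with phenyl in place of allyl on an aromatic carbon. Weak inhibition is expected to persist because an at least 5.8-fold higher number from compound 1 to compound 2 (0.76 log units; beyond the scatter) went toward weaker inhibition, and that is the only measured step to go on. The expected change is small, with a step that the limit leaves unreadable from compound 2 to compound 3 as the estimate. In this assay compound 3 is estimated at 1500 nM with an expected range of 500 nM to 5000 nM.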

Compound 3, half-maximal inhibitory concentration: 239 nM
For compound 3 the middle estimate is 6.3-fold (0.80 log units) above the measured one, outside the stated range (below it).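

In this assay, phenyl in place of allyl gives an at least 5.0-fold lower number from compound 2 to compound 3 (0.70 log units; beyond the scatter) and phenyl in place of vinyl gives a 1.2-fold higher number from compound 1 to compound 3 (0.07 log units; within the scatter) so these two groups read alike at this position. Adding heavy atoms here therefore need not weaken inhibition, and among these three compounds only compound 2, with allyl, stands apart. The first step is only a bound, because compound 2 rests on a limit and not a number: the limit of > 1200 nM in this assay, at which 1 of the 3 values shown sits. Still open, from the compounds shown here alone, is how an amine, a carboxylic acid or a chain longer than allyl would read at this position.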